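The source may hold more compounds than are shown below. What is called first, only, known or untested is meant among the compounds shown, and "the series" means these compounds.

Measured so far in a functional assay on Jurkat cells for inhibition of nuclear factor NF-kappa-B complex (Homo sapiens); a higher number here means a weaker inhibitor, a lower number a stronger inhibitor:
compound 1 `CCOC(=O)c1cnc(SC)nc1NN1C(=O)C=C(C)C1=O` — 200 nM
compound 2 `CCOC(=O)c1cnc(-c2csc(C)n2)nc1NN1C(=O)C=C(C)C1=O` — 8000 nM
compound 3 `CCOC(=O)c1cnc(-c2ccc(OC)cc2)nc1NN1C(=O)C=C(C)C1=O` — 900 nM

Compound 1 stands lowest of the three; the nearest is compound 3 and the furthest compound 2, both beyond the scatter. The next step goes from compound 1 to compound 4 `CCOC(=O)c1cnc(-c2ccsc2)nc1NN1C(=O)C=C(C)C1=O` through (thiophen-3-yl in place of methylsulfanyl on an aromatic carbon). Within the data shown here, two measured steps bear on it, both exchanging the same methylsulfanyl for an aromatic ring at the same position: a 40-fold higher number from compound 1 to compound 2 (1.60 log units; beyond the scatter) and a 4.5-fold higher number from compound 1 to compound 3 (0.65 log units; beyond the scatter). Both raise the number; the five-membered ring raised it far more than the six-membered one. A rise beyond the scatter is therefore expected for compound 4, in an estimated 10-fold higher number from compound 1 to compound 4 (1.00 log units; beyond the scatter). Compound 4 is estimated at 2000 nM in this assay, with a range of 600 nM to 7000 nM.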

Compound 4, half-maximal inhibitory concentration: 100 nM
Beside the measured number, compound 4's estimate is 20-fold (1.30 log units) above it, outside the stated range (below it).
By their numbers in this assay, from the lowest: compounds 4 and 1 (each within the scatter of the next); then compound 3; then compound 2.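

In this assay an aromatic ring on this carbon between two ring nitrogen atoms carries no penalty of its own, since a 2.0-fold lower number from compound 1 to compound 4 (0.30 log units; within the scatter) leaves thiophen-3-yl level with methylsulfanyl. The identity of the ring decides the number, with a 9.0-fold lower number from compound 3 to compound 4 (0.95 log units; beyond the scatter) and an 80-fold lower number from compound 2 to compound 4 (1.90 log units; beyond the scatter) across the aromatic groups, and compound 2 and compound 4 both hold five-membered rings, so ring size alone does not set it. No evidence on the cause of these differences is available.

Open, as far as these compounds go, is whether thiophen-2-yl matches thiophen-3-yl. Also open, from the compounds shown here alone, is whether an amine such as morpholin-4-yl at this carbon stays in the same range.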